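Replacing 2-methoxyphenyl with 3-bromophenyl in compound 3

The compounds below may be only part of what the source reports. "The series", "measured", "known", "first", "only" and "open" are said of these compounds alone.

Measured in a functional assay on HT-29 cells (Homo sapiens) for antiproliferative activity, read by sulforhodamine B assay, with a stated time of 48 h; a lower number here means a stronger inhibitor, a higher number a weaker inhibitor:
- compound 1 `COc1ccccc1OS(=O)(=O)c1ccc(N2CCN(C)C2=O)cc1`: 26000 nM
- compound 2 `Cc1cccc(OS(=O)(=O)c2ccc(N3CCN(C)C3=O)cc2)c1`: 4300 nM
- compound 3 `CCN1CCN(c2ccc(S(=O)(=O)Oc3ccccc3OC)cc2)C1=O`: > 100000 nM (a limit)

Compound 3 stands at a limit and not at a number, > 100000 nM. Compound 4 `CCN1CCN(c2ccc(S(=O)(=O)Oc3cccc(Br)c3)cc2)C1=O`, not yet measured, carries 3-bromophenyl in place of 2-methoxyphenyl on the oxygen bound to the sulfonyl sulfur: 3-bromophenyl in place of 2-methoxyphenyl on an oxygen. The closest measured change is a 6.0-fold lower number from compound 1 to compound 2 (0.78 log units; beyond the scatter), with 3-methylphenyl in place of 2-methoxyphenyl. Going by the values given here, the other measured change, an at least 3.8-fold higher number from compound 1 to compound 3 (0.58 log units; beyond the scatter), lies in a part that compound 3 and compound 4 share, so it gives no step of its own here. Going by these compounds, a step of similar size toward a lower number is therefore expected in this assay, though its exact size stays open without a number for compound 3. The estimated change is an at least 5.0-fold lower number from compound 3 to compound 4 (0.69 log units; beyond the scatter). For compound 4 the expected value is 20000 nM, with an estimated range from 5000 nM to 90000 nM.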

Compound 4, half-maximal inhibitory concentration: 3800 nM
Compound 4: the middle estimate sits 5.3-fold (0.72 log units) above what was measured, and the stated range ends above it.
By their numbers in this assay, from the lowest: compounds 4 and 2 (each within the scatter of the next); then compound 1. At a limit, above all of these: compound 3.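

In this assay, the group on the oxygen bound to the sulfonyl sulfur also counts on the core of compound 3, where 3-bromophenyl in place of 2-methoxyphenyl gives an at least 26-fold lower number from compound 3 to compound 4 (1.42 log units; beyond the scatter). The value of compound 3, > 100000 nM, is a limit, so this step is a bound and not a measured size: the limit of > 100000 nM in this assay, at which 1 of the 4 values shown sits.

The earlier step with 3-methylphenyl stood on the core of compound 1, so leaving 2-methoxyphenyl behind now gives a lower number on both cores shown. Going by these compounds, what 3-aminophenyl or 3-carboxyphenyl would give on that oxygen stays open, as does how 3-bromophenyl and 3-methylphenyl compare on one core.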